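The compounds below may be only part of what the source reports. "The series", "measured", "known", "first", "only" and "open" are said of these compounds alone.

Within the data shown here, only two compounds have been measured so far. Compound 1 `C#Cc1cccc(Nc2ncnc3ccc(NC(=O)c4ccc(C(=O)Nc5ccccc5N)s4)cc23)c1` reports > 50000 nM in a functional assay on A549 cells (Homo sapiens) for cytotoxicity, read by resazurin assay (a higher number here means a weaker inhibitor, a lower number a stronger inhibitor), and this is a limit of the assay, not a number. Among the measured compounds shown here, compound 2 `C#Cc1cccc(Nc2ncnc3ccc(OCc4ccc(C(=O)Nc5ccccc5N)cc4)cc23)c1` gives 900 nM in this assay as the only actual number available. Compound 3 `Nc1ccccc1NC(=O)c1ccc(COc2ccc3ncnc(Nc4cccc(Br)c4)c3c2)cc1` differs from compound 2 in one place (bromo in place of ethynyl on an aromatic carbon) with bromo in place of ethynyl on an aromatic carbon, meta to a large group. For the measured compounds named here, no measured pair shows this kind of swap, so the expectation in this assay rests on compound 2 at 900 nM and the small size of the change, with little or no shift expected beyond the scatter. The expected change is a 1.3-fold higher number from compound 2 to compound 3 (0.12 log units; within the scatter) and the direction is uncertain. Compound 3 is estimated at 1200 nM with an expected range from 350 nM to 4500 nM in this assay.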

Compound 3, half-maximal inhibitory concentration: 1300 nM
Compound 3: the middle estimate sits 1.1-fold (0.03 log units) below what was measured; the range from low to high includes it.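

Replacing ethynyl with bromo, the change from 3-ethynylphenyl to 3-bromophenyl on an aromatic carbon meta to a large group, gives a 1.4-fold higher number from compound 2 to compound 3 (0.16 log units; within the scatter) in this assay. Among these compounds, this is the first pair that differs in one place, and it shows that in this assay the two groups cannot be told apart at this position, although the heavy atoms there go from two carbons to one bromine. Nothing at hand gives a cause for this step.

From the compounds shown here alone, whether the same holds for other groups at this position, such as a chloro, a methoxy or an amine, remains open. Going by these compounds, it is also open whether the match between ethynyl and bromo carries over to compounds that differ elsewhere in the molecule.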